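A few compounds are considered here, and "the series" means these few. Any claim that something is new, unique, unknown or untested is made for them only; others in the source may bear on it.

Compound 1 `Cc1cc(-c2sc(Cc3cccc(C(F)(F)F)c3)nc2C)ccc1C(N)=O` gives 86%
Compound 2 `Cc1nc(Cc2cccc(C(F)(F)F)c2)sc1-c1ccc(C(N)=O)c(C(C)C)c1` gives 63%
Compound 3 `COc1cc(-c2sc(Cc3cccc(C(F)(F)F)c3)nc2C)ccc1C(N)=O` gives 88%

These three values come from a functional assay on cells for agonist activity at G-protein coupled receptor 52 (Homo sapiens), read by AlphaScreen and cAMP accumulation, with a stated time of 30 min; on this read-out lower numbers stand for smaller maximal responses and higher numbers for larger maximal responses. Compound 1 stands second highest of the three; its nearest neighbour is compound 3, whose value lies within the scatter of it, while compound 2 sits further off, a number 23 percentage points lower from compound 1 to compound 2 (beyond the scatter). Compound 4 `COc1cccc(Cc2nc(C)c(-c3ccc(C(N)=O)c(C)c3)s2)c1` differs from compound 1 in one place: methoxy in place of trifluoromethyl on an aromatic carbon. Among the measured compounds shown here, none of the measured steps touches this part of the molecule; both measured steps concern the other ring, one of them being a number 2 percentage points higher from compound 1 to compound 3 (within the scatter). For the measured compounds named here, with no step bearing on the methoxy in place of trifluoromethyl, the account expects no change beyond the scatter in this assay, that is a number 3 percentage points lower from compound 1 to compound 4 (within the scatter). Compound 4 is therefore estimated at 83%, between 62% and 100%.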

Compound 4, largest response reached (Emax), in percent of the reference or control that the assay uses: 85%
Estimate against measurement, compound 4: 2 percentage points below; low and high end bracket the measured number.
By their numbers in this assay, from the lowest: compound 2; then compounds 4, 1 and 3 (each within the scatter of the next).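

In this assay, the first change shown on this ring, methoxy in place of trifluoromethyl on the aromatic carbon meta to a large group, comes to a number 1 percentage points lower from compound 1 to compound 4 (within the scatter). The maximal response therefore holds across this exchange, although the entering group has fewer heavy atoms and adds a hydrogen-bond acceptor. Nothing available explains why the response holds. On these data alone, it remains open whether an amine or a carboxylic acid on this same carbon would also preserve the maximal response.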